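The source may hold more compounds than are shown below. What is called first, only, known or untested is meant among the compounds shown, and "the series" means these compounds.

Three compounds sharing one core, and differing only in the length of a straight chain on it, have been measured in a functional assay on L1210 cells (Mus musculus); on this read-out higher numbers stand for weaker inhibition and lower numbers for stronger inhibition. Compound 1 `CCCCCCCCc1cn([C@H]2C[C@H](O)[C@@H](CO)O2)c(=O)[nH]c1=O`, carrying the longest chain, gives 66 ug/mL. Compound 2 `CCCCc1cn([C@H]2C[C@H](O)[C@@H](CO)O2)c(=O)[nH]c1=O` gives only a limit of the assay, > 500 ug/mL. Compound 3 `CCCCCc1cn([C@H]2C[C@H](O)[C@@H](CO)O2)c(=O)[nH]c1=O` gives 476 ug/mL, which is the highest of the two plain numbers; the nearest is compound 1, with a 7.2-fold higher number from compound 1 to compound 3 (0.86 log units; beyond the scatter). Between compound 2 and compound 3 the step is an at least 1.0-fold lower number from compound 2 to compound 3 (0.02 log units; that floor lies within the scatter), so the two cannot be told apart.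

Compound 4 `CCCc1cn([C@H]2C[C@H](O)[C@@H](CO)O2)c(=O)[nH]c1=O` shortens the chain again: hydrogen in place of ethyl on a saturated chain carbon, three bonds along the chain from an aromatic carbon. Among the measured compounds shown here, the steps that bear on this all run the same way: cutting the chain from compound 1 gave an at least 7.5-fold higher number from compound 1 to compound 2 (0.87 log units; beyond the scatter) and a 7.2-fold higher number from compound 1 to compound 3 (0.86 log units; beyond the scatter), and the further shortening from compound 3 to compound 2 gave nothing beyond the scatter, since compound 2 sits at the limit of > 500 ug/mL in this assay, at which 1 of the 3 values shown sits. Removing two more chain carbons from compound 3 is therefore expected to give no lower number, and most likely a limit again. The step from compound 3 to compound 4 in this assay is estimated at a 1.4-fold higher number from compound 3 to compound 4 (0.14 log units; within the scatter). Compound 4 is expected to give about 650 ug/mL, within a range from 400 ug/mL to 1500 ug/mL.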

Compound 4, concentration for 50% inhibition: > 500 ug/mL
Compound 4: only a limit was reported; the forecaster's own chance of this, stated with the estimate: 70%; the middle value lies beyond the limit too.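

With the chain cut back to propyl, this assay still separates nothing among the short chains: an at least 1.0-fold higher number from compound 3 to compound 4 (0.02 log units; that floor lies within the scatter), so compound 3 and compound 4 cannot be told apart. Set against the longest chain, the propyl chain gives an at least 7.5-fold higher number from compound 1 to compound 4 (0.87 log units; beyond the scatter), which extends the clear gap already seen for the butyl and pentyl chains and leaves compound 1 as the only compound shown that stands apart from the rest. The step between compound 2 and compound 4 cannot be read, since both values are limits, and the short chains now gather at a single limit of the assay: the limit of > 500 ug/mL in this assay, at which 2 of the 4 values shown sit.

The compounds shown leave open where between the pentyl chain and the longest chain the numbers begin to fall, which a hexyl or heptyl chain could help to place, and whether a still longer chain would bring them lower than in compound 1. From the compounds shown here alone, it also remains open whether the chain must be a plain hydrocarbon, or whether one ending in an amine or a carboxylic acid would give a readable number.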